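This account rests on a few compounds, and the source may have more. Where it says the series, first, only, none or still open, it means among the compounds named here.

Values measured in a functional assay on NCI-H460 cells (Homo sapiens) for cytotoxicity, read by MTT assay, with a stated time of 48 h; on this read-out lower numbers stand for stronger inhibition and higher numbers for weaker inhibition:

- Compound 1 `C=C1C(=O)O[C@H]2CC3=C[C@H](C/C(C)=C/[C@@H](OC(=O)/C=C/c4ccccc4)[C@H]12)OC3=O`: > 10000 nM, a limit
- Compound 2 `C=C1C(=O)O[C@H]2CC3=C[C@H](C/C(C)=C/[C@@H](OC(=O)CCCCBr)[C@H]12)OC3=O`: > 10000 nM, a limit
- Compound 3 `C=C1C(=O)O[C@H]2CC3=C[C@H](C/C(C)=C/[C@@H](OC(=O)CC4CCCCC4)[C@H]12)OC3=O`: 2000 nM

For the measured compounds named here, compound 3 holds the only true number in this small set. Compound 1 and compound 2 stand at the limit of > 10000 nM in this assay, at which 2 of the 3 values shown sit.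

Compound 4 `C=C1C(=O)O[C@H]2CC3=C[C@H](C/C(C)=C/[C@@H](OC(=O)CC(C)C)[C@H]12)OC3=O` differs from compound 3 by a single change: isopropyl in place of cyclohexyl on a saturated chain carbon bound to a carbonyl carbon. In words, it carries isopropyl in place of cyclohexyl on a saturated chain carbon bound to a carbonyl carbon.

Going by the values given here, two measured steps bear on this change: an at least 5.0-fold lower number from compound 1 to compound 3 (0.69 log units; beyond the scatter) and an at least 5.0-fold lower number from compound 2 to compound 3 (0.69 log units; beyond the scatter). Both start from a limit, so each gives only a minimum size. Neither replaces cyclohexyl with isopropyl. Still, the second step shows that the group at this same place can move the result in this assay, so a shift toward a higher number is the likelier direction. The expected change is small and not beyond the scatter, estimated as a 1.5-fold higher number from compound 3 to compound 4 (0.18 log units; within the scatter). For compound 4 the estimated value is 3000 nM, with an expected range from 1000 nM to 10000 nM.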

Compound 4, half-maximal inhibitory concentration: 3800 nM
Beside the measured number, compound 4's estimate is 1.3-fold (0.10 log units) below it; measured number inside the range.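

With isopropyl in place of cyclohexyl, this assay gives a 1.9-fold higher number from compound 3 to compound 4 (0.28 log units; within the scatter), so at this place the cyclohexyl ring is not needed for a true number, even with 3 heavy atoms in place of 6. Two further steps, an at least 2.6-fold lower number from compound 2 to compound 4 (0.42 log units; beyond the scatter) and an at least 2.6-fold lower number from compound 1 to compound 4 (0.42 log units; beyond the scatter), both start from a limit and so give minimum sizes only. Cyclohexyl and isopropyl thus both give a true number at this place, while 3-bromopropyl in compound 2 stays at a limit: the limit of > 10000 nM in this assay, at which 2 of the 4 values shown sit.

The compounds shown leave open whether a methyl group or a longer unbranched chain at this place would still give a true number, and whether an amine or a carboxylic acid on the chain would do so. They also leave open whether any group here can reach a clearly lower number than compound 3 and compound 4.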